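Swapping 4-Methylphenyl for 3-Fluorophenyl on the Shared Core

The compounds below may be only part of what the source reports. "The series", "measured", "known", "first", "only" and "open" are said of these compounds alone.

Measured so far in a functional assay on HeLa cells (Homo sapiens) for antiproliferative activity, read by MTT assay, with a stated time of 72 h; a lower number here means a stronger inhibitor, a higher number a weaker inhibitor:
Compound 1 `COc1cc(-n2ncnc2-c2ccc(C)cc2)cc(OC)c1OC` gives 250 nM.
Compound 2 `COc1cc(-c2ncnn2-c2ccc(Cl)cc2Cl)cc(OC)c1OC` gives only an assay limit, > 10000 nM.
Compound 3 `COc1cc(-c2ncnn2-c2ccccc2)cc(OC)c1OC` gives only an assay limit, > 10000 nM.

Among the measured compounds shown here, compound 1 therefore holds the only real number; the other two entries are limits, as the limit of > 10000 nM in this assay, at which 2 of the 3 values shown sit, records. For the measured compounds named here, the single measured step, a step that the two limits leave unreadable from compound 2 to compound 3, cannot be sized and concerns a group on an aromatic nitrogen, so no measured step bears on the change at hand. Compound 4 `COc1cc(-n2ncnc2-c2cccc(F)c2)cc(OC)c1OC` differs from compound 1 by 3-fluorophenyl in place of 4-methylphenyl on an aromatic carbon. Going by the values given here, with no measured step to guide the direction, compound 4 is expected to come out somewhat weaker, an estimated step of a 3.2-fold higher number from compound 1 to compound 4 (0.51 log units; beyond the scatter) in this assay. The estimate for compound 4 is 800 nM, within 200 nM to 4000 nM.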

Compound 4, half-maximal inhibitory concentration: > 10000 nM
Compound 4 gave a limit, no number (the forecaster's own chance of this, stated with the estimate: 15%); middle value at least 12-fold (1.09 log units) from the limit.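

On this aromatic carbon of the five-membered ring, 3-fluorophenyl in place of 4-methylphenyl gives an at least 40-fold higher number from compound 1 to compound 4 (1.60 log units; beyond the scatter), even though both groups have one six-membered aromatic ring of carbon only and 7 heavy atoms. Among the compounds shown here, this is the first readable step in this assay, and it shows that activity at this position depends strongly on the group's exact makeup. Compound 4 gives only a limit, so the true size of the step remains unknown: the limit of > 10000 nM in this assay, at which 3 of the 4 values shown sit.

From the compounds shown here alone, how 3-methylphenyl or 4-fluorophenyl would behave remains open, and these groups could separate the effect of the fluorine from that of its place on the ring. Going by these compounds, whether 4-methoxyphenyl would keep the activity of compound 1 is also open.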